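Chloro for methyl on the N-aryl group of compound 1

This account rests on a few compounds, and the source may have more. Where it says the series, first, only, none or still open, it means among the compounds named here.

Measured compounds:
compound 1 `COc1ncc(-c2ccc3c(c2)N(c2ccc(C)cc2)C(=O)CO3)cc1NS(=O)(=O)c1ccc(F)cc1` in a functional assay on A-375 cells (Homo sapiens) for antiproliferative activity, read by MTT assay, with a stated time of 72 h (on this read-out higher numbers stand for weaker inhibition and lower numbers for stronger inhibition), gives 12900 nM
compound 2 `Cc1ccc(N2C(=O)COc3ccc(-c4cnc(Cl)c(NS(=O)(=O)c5ccc(F)cc5)c4)cc32)cc1` in this assay gives 38900 nM

Within the data shown here, compound 1 stands lowest of the two numbers so far; the only other number belongs to compound 2, reached by a 3.0-fold higher number from compound 1 to compound 2 (0.48 log units; beyond the scatter), which is a change of chloro in place of methoxy on an aromatic carbon.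

Compound 3 `COc1ncc(-c2ccc3c(c2)N(c2ccc(Cl)cc2)C(=O)CO3)cc1NS(=O)(=O)c1ccc(F)cc1` differs from compound 1 by chloro in place of methyl on an aromatic carbon. Among the measured compounds shown here, the one measured step also introduces a chloro, but it replaces methoxy rather than methyl, so it bears on the present change only loosely, and its modest size is the only guide. A chloro entering for methyl is a small swap in counted atoms; no step beyond the scatter is expected in this assay, with a slight lean toward a higher number. Compound 3 is therefore estimated at 14000 nM, within 5000 nM to 40000 nM, an expected step of a 1.1-fold higher number from compound 1 to compound 3 (0.04 log units; within the scatter).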

Compound 3, half-maximal inhibitory concentration: 24100 nM
The estimate for compound 3 lay 1.7-fold (0.24 log units) below the measured number, and the stated range covers the measured number.
By their numbers in this assay, from the lowest: compounds 1, 3 and 2 (each within the scatter of the next, the first and the last beyond it).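

Going from 4-methylphenyl to 4-chlorophenyl gives a 1.9-fold higher number from compound 1 to compound 3 (0.27 log units; within the scatter) in this assay. Among these compounds, this is the first reading at this position, as the earlier step changed only the methoxy. Para to a large group, methyl and chloro cannot be told apart on this read-out, so this pair sets no preference between them. No measurement at hand bears on the reason for this result.

Still open, going by these compounds, is how this position responds to groups of another kind, such as a dimethylamino group, a carboxylic acid or a morpholine in place of the methyl, and whether the plain phenyl with only a hydrogen there reads any differently. Also open, on these data alone, is whether a replacement at this position could bring a step beyond the scatter.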